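Plasma protein binding in a fused bicyclic ether series

The source may report more compounds than this note shows. Statements on the series, on what has been measured and on what is new or still open speak of the compounds shown alone.

Measured so far, in an ADME assay on a cell-free system (plasma, Mus musculus) for protein binding, using equilibrium dialysis, tested at 10 uM:
compound 1 `NC(=O)c1c(F)ccc(OCc2nc3cc(-c4ccccc4)ccc3s2)c1F` gives 99.2%
compound 2 `CCOc1ccc2sc(COc3ccc(F)c(C(N)=O)c3F)nc2c1` gives 96.4%
compound 3 `CCOc1cnc2sc(COc3ccc(F)c(C(N)=O)c3F)nc2c1` gives 89.9%

Compound 3 holds the highest unbound fraction of the three; its nearest neighbour is compound 2, and compound 1 sits furthest from it. The step from compound 3 to compound 4 `NC(=O)c1c(F)ccc(OCc2nc3cc(-c4ccccc4)cnc3s2)c1F` is phenyl in place of ethoxy on an aromatic carbon.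

Within the data shown here, one measured step bears on this change, in the opposite direction: a 4.5-fold higher unbound fraction from compound 1 to compound 2 (0.65 log units; beyond the scatter). Compound 1 and compound 2 share the core of compound 3 only in part, as their fused system carries no ring nitrogen, but the exchanged groups are the same pair. Reversing that step, phenyl in place of ethoxy is expected to lower the unbound fraction of compound 4 by a step of about the same size, well beyond the scatter, so that compound 4 should move back toward the binding seen for compound 1.

For compound 4 in this assay the estimate is 97.8%, with a range from 96% to 99%; this corresponds to the expected step a 4.6-fold lower unbound fraction from compound 3 to compound 4 (0.66 log units; beyond the scatter).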

Compound 4, plasma protein binding: 98.5%
The estimate for compound 4 lay 1.5-fold (0.17 log units) (unbound fraction) above the measured number; low and high end bracket the measured number.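

In this assay, the exchange of ethoxy for phenyl now reads on a second core, where the aromatic carbon sits in a six-membered aromatic ring with 1 nitrogen: a 6.7-fold lower unbound fraction from compound 3 to compound 4 (0.83 log units; beyond the scatter). With phenyl at this position, compound 1 gives 99.2% and compound 4 gives 98.5%, so the higher unbound fraction of compound 3 does not persist once ethoxy leaves. The change therefore carries over from the core of compound 1 to the core of compound 3, with a step of matching size on both: the same change on two cores in this assay, a 4.5-fold higher unbound fraction (0.65 log units; beyond the scatter) from compound 1 to compound 2 and a 6.7-fold higher unbound fraction (0.83 log units; beyond the scatter) from compound 4 to compound 3, 1.5-fold (0.18 log units) apart, within the scatter of two such steps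

The compounds shown hold only ethoxy and phenyl at this position, so they do not separate the contribution of the aromatic ring from that of the larger number of heavy atoms. On these data alone, how an amine, a carboxylic acid or a longer ether chain on this aromatic carbon would shift the binding in this assay remains open, as does whether the step holds on any core other than these two.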